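Aryl for methyl on a ring amide nitrogen

The compounds below may be only part of what the source reports. "The series", "measured", "known", "first", "only" and "open" are said of these compounds alone.

Measured compounds:
Compound 1 `CC(C)[C@@H]1CC[C@@H](C)C[C@@]12N(C)C(=O)[C@@H]1[C@H]3C(=O)NC(=O)[C@H]3ON12` gives 21.6% in a functional assay, with a stated time of 20 min, tested at 0.5 mg/mL; on this read-out higher numbers stand for a stronger effect at the one concentration tested and lower numbers for a weaker effect.
Compound 2 `CC(C)[C@@H]1CC[C@@H](C)C[C@@]12N(C)C(=O)[C@@H]1[C@H]3C(=O)N(C)C(=O)[C@H]3ON12` gives 18.2% in this assay.
Compound 3 `CC(C)[C@@H]1CC[C@@H](C)C[C@@]12N(C)C(=O)[C@@H]1[C@H]3C(=O)N(c4ccc(Cl)cc4)C(=O)[C@H]3ON12` gives 18.1% in this assay.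

All three share one core and differ only in the group on an amide-type nitrogen in a ring. The three numbers lie close together: compound 2 sits among values that are all within the usual scatter of each other, with a number 3.4 percentage points lower from compound 1 to compound 2 (within the scatter) and a number 0.1 percentage points lower from compound 2 to compound 3 (within the scatter).

Compound 4 `Cc1cccc(N2C(=O)[C@H]3[C@H](ON4[C@@H]3C(=O)N(C)[C@@]43C[C@H](C)CC[C@H]3C(C)C)C2=O)c1` is not yet measured. It differs from compound 2 in one place: 3-methylphenyl in place of methyl on an amide-type nitrogen in a ring. The closest guide is the step in which 4-chlorophenyl replaced methyl, a number 0.1 percentage points lower from compound 2 to compound 3 (within the scatter), which stayed within the scatter. The move from hydrogen to 4-chlorophenyl, a number 3.5 percentage points lower from compound 1 to compound 3 (within the scatter), also stayed within the scatter. So putting an aromatic ring on this nitrogen has so far not shifted the read-out in this assay, and no step beyond the scatter is expected for 3-methylphenyl either.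

For compound 4 the expected value in this assay is therefore 18%, with a range from 10% to 26%, meaning an expected step of a number 0.2 percentage points lower from compound 2 to compound 4 (within the scatter).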

Compound 4, a percentage reported as activity, at one concentration (the size of the read-out at that concentration, not a potency): 26.8%
Estimate against measurement, compound 4: 8.8 percentage points below; measured number outside the range, above it.
By their numbers in this assay, from the lowest: compounds 3, 2, 1 and 4 (each within the scatter of the next).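

With 3-methylphenyl on this amide-type nitrogen, seven heavy atoms and an aromatic ring take the place of a single methyl carbon, yet in this assay the result is a number 8.6 percentage points higher from compound 2 to compound 4 (within the scatter). The comparisons with the other two groups are a number 8.7 percentage points higher from compound 3 to compound 4 (within the scatter) and a number 5.2 percentage points higher from compound 1 to compound 4 (within the scatter), so hydrogen, methyl, 4-chlorophenyl and 3-methylphenyl at this position cannot be told apart on this read-out. No measurement is available that could explain these numbers.

From the compounds shown here alone, it remains open whether a longer alkyl chain on this nitrogen, or a phenyl ring carrying an amine or a carboxylic acid, would give a step beyond the scatter. Compounds 3 and 4 differ in both the substituent on the phenyl ring and its location, so 4-methylphenyl would be needed to separate those two changes.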